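A new sulfur-linked ring in place of 4-methylpiperazin-1-yl

The compounds below may be only part of what the source reports. "The series", "measured", "known", "first", "only" and "open" are said of these compounds alone.

For the measured compounds named here, in a functional assay on MCF7 cells (Homo sapiens) for inhibition, read by MTT assay, with a stated time of 72 h (a higher number here means a weaker inhibitor, a lower number a stronger inhibitor), compound 1 `CN1CCN(c2cc(C(F)(F)F)nc(SCc3ccc(C(F)(F)F)cc3)n2)CC1` gives 30200 nM, the higher of the two exact numbers so far, while compound 2 `Cc1csc(Sc2cc(C(F)(F)F)nc(SCc3ccc(C(F)(F)F)cc3)n2)n1` gives 14500 nM. Compound 3 `FC(F)(F)c1ccc(CSc2nc(Sc3ncccn3)cc(C(F)(F)F)n2)cc1` reads > 50000 nM, which is a limit of the assay and not a number. Compound 4 `Cc1nnc(Sc2cc(C(F)(F)F)nc(SCc3ccc(C(F)(F)F)cc3)n2)s1` has not yet been measured. It carries (5-methyl-1,3,4-thiadiazol-2-yl)sulfanyl in place of 4-methylpiperazin-1-yl on an aromatic carbon.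

Two measured steps make a similar exchange: (4-methyl-1,3-thiazol-2-yl)sulfanyl gives a 2.1-fold lower number from compound 1 to compound 2 (0.32 log units; beyond the scatter), and (pyrimidin-2-yl)sulfanyl gives an at least 1.6-fold higher number from compound 1 to compound 3 (0.21 log units; that floor lies within the scatter). These two outcomes differ from each other, as an at least 3.4-fold higher number from compound 2 to compound 3 (0.53 log units; beyond the scatter) shows, so the choice of incoming ring matters. They point in opposite directions, so no step beyond the scatter is expected in this assay. The expected step is a 1.4-fold lower number from compound 1 to compound 4 (0.14 log units; within the scatter). Compound 4 is estimated at 22000 nM, with an expected range from 9000 nM to 55000 nM.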

Compound 4, half-maximal inhibitory concentration: > 50000 nM
Compound 4: no number, only a limit (the forecaster's own chance of this, stated with the estimate: 25%); middle value at least 2.2-fold (0.35 log units) away from the limit.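

In this assay, the thiadiazole does not keep the gain seen with the thiazole: 5-methyl-1,3,4-thiadiazol-2-yl in place of 4-methyl-1,3-thiazol-2-yl gives an at least 3.4-fold higher number from compound 2 to compound 4 (0.53 log units; beyond the scatter). So a five-membered aromatic ring carrying a methyl group and joined through sulfur is not enough to hold the number of compound 2, and the exact ring matters at this position. Set against the piperazine, the same ring gives an at least 1.6-fold higher number from compound 1 to compound 4 (0.21 log units; that floor lies within the scatter), so of the three sulfur-linked rings shown, only compound 2 has an exact number, and the step between compound 3 and compound 4 cannot be read: the limit of > 50000 nM in this assay, at which 2 of the 4 values shown sit.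

Going by these compounds, how far past that limit compound 3 and compound 4 lie remains open. So does what a morpholin-4-yl ring or an open-chain amine such as dimethylamino would do at this position.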